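Naphthyl sulfonamide series: aryl change at the imidazole carbon

The source may hold more compounds than are shown below. What is called first, only, known or untested is meant among the compounds shown, and "the series" means these compounds.

Compound 1 `COc1cc(-c2nc(-c3ccccc3)[nH]c2-c2ccnc(NCCCNS(=O)(=O)c3ccccc3)n2)ccc1F` is the reference point of the pair. In a functional assay on LOX IMVI cells (Homo sapiens) for cytotoxicity, read by MTT assay, with a stated time of 24 h (on this read-out higher numbers stand for weaker inhibition and lower numbers for stronger inhibition), compound 1 gives 4520 nM. Compound 2 `COc1cc(-c2nc(-c3ccccc3)[nH]c2-c2ccnc(NCCCNS(=O)(=O)c3cccc4ccccc34)n2)ccc1F` carries the larger sulfonyl aryl group, and in this assay compound 2 gives 14900 nM. Among the measured compounds shown here, the single measured step, a 3.3-fold higher number from compound 1 to compound 2 (0.52 log units; beyond the scatter), is the only comparison so far. For the measured compounds named here, compound 2 therefore stands at the highest number of the two measured compounds, with compound 1 as its only neighbour at the lower number.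

Compound 3 `O=S(=O)(NCCCNc1nccc(-c2[nH]c(-c3ccccc3)nc2-c2ccc(Cl)c(O)c2)n1)c1cccc2ccccc12` is not yet measured. It differs from compound 2 as follows: 4-chloro-3-hydroxyphenyl in place of 4-fluoro-3-methoxyphenyl on an aromatic carbon. Going by the values given here, this change sits far from the sulfonyl sulfur, where the only measured step was taken, so no measured step bears on it; the step from compound 1 to compound 2 gives no guide to a swap of this aryl group. Among the compounds with values here, with no relevant precedent, no step beyond the scatter is expected in either direction, and the estimate for compound 3 is anchored on compound 2, namely a 1.2-fold lower number from compound 2 to compound 3 (0.09 log units; within the scatter). Compound 3 is therefore expected to give about 12000 nM in this assay, within a range from 4000 nM to 40000 nM.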

Compound 3, half-maximal inhibitory concentration: 7720 nM
Beside the measured number, compound 3's estimate is 1.6-fold (0.19 log units) above it; the range from low to high includes it.
By their numbers in this assay, from the lowest: compounds 1, 3 and 2 (each within the scatter of the next, the first and the last beyond it).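

Among the compounds shown here, this is the first measured step at the aryl group on the aromatic carbon of the five-membered ring, and in this assay the swap to 4-chloro-3-hydroxyphenyl gives a 1.9-fold lower number from compound 2 to compound 3 (0.29 log units; within the scatter). For the compounds shown here, on the naphthalen-1-yl sulfonyl background, therefore, this position tolerates a change of both substituents together, including the entry of a hydrogen-bond donor, without a step beyond the scatter, whereas the only earlier step was taken at the sulfonyl sulfur and was beyond it. No supporting measurement is available to explain this result.

Since halogen and oxygen substituent change together in this one step, their separate contributions stay unresolved, and a 4-chloro-3-methoxyphenyl or 4-fluoro-3-hydroxyphenyl group would be needed to separate them. Also open, going by these compounds, are whether the step at the sulfonyl sulfur carries over to the 4-chloro-3-hydroxyphenyl background, and whether an amine on this aryl ring or a longer chain in place of the present linker would move the number beyond the scatter.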